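One Stereocentre Redrawn from Compound 2 to Compound 4

The source may report more compounds than this note shows. Statements on the series, on what has been measured and on what is new or still open speak of the compounds shown alone.

Values measured so far in a physicochemical assay for solubility, in phosphate buffer (a lower number here means a less soluble compound, a higher number a more soluble compound), are these
compound 1 `C[C@H]1CN([C@@H](C)CO)C(=O)c2cccc(NC(=O)c3ccncc3)c2O[C@@H]1CN(C)Cc1ccc(Cl)c(Cl)c1` gives 64000 nM
compound 2 `C[C@H](CO)N1C[C@H](C)[C@H](CN(C)Cc2ccc(Oc3ccccc3)cc2)Oc2c(NC(=O)c3ccncc3)cccc2C1=O` gives 98000 nM
compound 3 `C[C@H]1CN([C@@H](C)CO)C(=O)c2cccc(NC(=O)c3ccncc3)c2O[C@@H]1CN(C)Cc1ccccc1` gives 100000 nM

Compound 2 at 98000 nM lies within the scatter of both compound 1 and compound 3, so the three values form a single group. Passing from compound 2 to compound 4 `C[C@@H]1CN([C@H](C)CO)C(=O)c2cccc(NC(=O)c3ccncc3)c2O[C@H]1CN(C)Cc1ccc(Oc2ccccc2)cc1` brings the two compounds have the same atoms and bonds and differ only in configuration as drawn: 1 of 3 stereo elements differ; a stereocentre at a saturated ring carbon is drawn S in compound 2 and R in compound 4 and nothing enters or leaves. For the measured compounds named here, the one measured step is a 1.6-fold higher number from compound 1 to compound 3 (0.19 log units; within the scatter) and it lies within the scatter. That step puts phenyl in place of 3,4-dichlorophenyl and leaves the configuration as drawn untouched, so it bears on this change only indirectly. Going by the values given here, no measured pair differs in configuration alone, and the data therefore give no direct guide and favour no direction. The expected step is a 1.0-fold lower number from compound 2 to compound 4 (0.01 log units; within the scatter) and it is expected to stay within the scatter in this assay as the measured values have so far. For compound 4 the estimate is 95000 nM and the expected range runs from 55000 nM to 140000 nM when the measurement is made.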

Compound 4, solubility: 1000 nM
For compound 4 the middle estimate is 95-fold (1.98 log units) above the measured one, outside the stated range (below it).
By their numbers in this assay, from the lowest: compound 4; then compounds 1, 2 and 3 (each within the scatter of the next).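

In this assay, redrawing one stereocentre at a saturated ring carbon from S to R gives a 98-fold lower number from compound 2 to compound 4 (1.99 log units; beyond the scatter), so this position responds strongly to configuration. For the compounds shown here, the only earlier step, a 1.6-fold higher number from compound 1 to compound 3 (0.19 log units; within the scatter), exchanged 3,4-dichlorophenyl for phenyl and showed no such sensitivity, as it stayed within the scatter. The large step belongs to this single stereocentre, because nothing else separates the two structures: the fact that compounds 2 and 4 differ only in the configuration as drawn

On these data alone, whether the same redrawing would have a similar effect on compound 1 or compound 3, and whether the other two stereo elements matter as much, remains open. As far as these compounds go, it is equally open whether this sensitivity to configuration would persist with a carboxylic acid in place of the aryl group on the amine side chain.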